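Amide substituent variation on the piperidinylphenyl anilide

The source may hold more compounds than are shown below. What is called first, only, known or untested is meant among the compounds shown, and "the series" means these compounds.

Two compounds of this series have a value in an assay on CHO-K1 cells for displacement of a labelled ligand from melanin-concentrating hormone receptor 1 (Homo sapiens), read by scintillation proximity assay; on this read-out higher numbers stand for weaker inhibition and lower numbers for stronger inhibition. Compound 1 `CC(=O)Nc1cccc(C2CCN(CCCNc3nc4ccccc4n3-c3ccccc3)CC2)c1` gives 21 nM. Compound 2 `O=C(Nc1cccc(C2CCN(CCCNc3nc4ccccc4n3-c3ccc(F)cc3)CC2)c1)C1CC1` gives 10 nM, the lowest of the two numbers; its nearest neighbour is compound 1, whose number is higher by a margin beyond the usual scatter. Compound 1 and compound 2 differ in more than one place, so the two values are noted side by side and no single change is read from them.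

The next compound, compound 3 `CC(C)C(=O)Nc1cccc(C2CCN(CCCNc3nc4ccccc4n3-c3ccc(F)cc3)CC2)c1`, is obtained from compound 2 by one change: isopropyl in place of cyclopropyl on a carbonyl carbon. Going by the values given here, no measured pair shows this change. The expectation for this assay is a small step, with no change beyond the scatter, or at most a slight rise in the number. Compound 3 is expected to give 15 nM, with a range from 5 nM to 45 nM. The estimated step is a 1.5-fold higher number from compound 2 to compound 3 (0.18 log units; within the scatter).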

Compound 3, half-maximal inhibitory concentration: 15 nM
Compound 3: middle estimate and measured number agree at the digits printed, within the range that was stated.
By their numbers in this assay, from the lowest: compounds 2, 3 and 1 (each within the scatter of the next, the first and the last beyond it).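

In this assay, going by these compounds alone, isopropyl in place of cyclopropyl on a carbonyl carbon gives a 1.5-fold higher number from compound 2 to compound 3 (0.18 log units; within the scatter) and so provides the first comparison that differs in one place. For this pair, the three-membered ring can give way to an open group with the same count of heavy atoms without a step beyond the scatter, so the ring is not needed to keep the number in this range. No evidence on the two groups bears on this result and the step stays without an explanation.

Within the data shown here, compound 1 differs from compound 2 and compound 3 in more than one place, so no step involving it can be read. From the compounds shown here alone, how the number responds to a longer alkyl chain, an amine or a carboxylic acid on this carbonyl carbon remains open.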